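The compounds below may be only part of what the source reports. "The series", "measured", "known", "first", "only" and "open" are said of these compounds alone.

In a functional assay on U-251 cells (Homo sapiens) for inhibition, read by sulforhodamine B assay, with a stated time of 48 h (on this read-out higher numbers stand for weaker inhibition of growth and lower numbers for stronger inhibition of growth), compound 3 `CC(C)(C)NCc1c(C(=O)O)nn(-c2ccccc2)c1-c1ccccc1` gives > 716000 nM, which is a limit of the assay and not a number. Compound 2 `CC(C)(C)NCc1c(C(=O)O)nn(-c2ccccc2)c1-c1ccc(Br)cc1`, which carries a bromo group on that ring, gives 126000 nM. Compound 1 `CCOC(=O)c1nn(-c2ccccc2)c(-c2ccc(C)cc2)c1CNC(C)(C)C` gives 65400 nM; > 585000 nM (2 entries), and these several entries guide only loosely. Compound 4 `Cc1ccc(-c2c(CNC(C)(C)C)c(C(=O)O)nn2-c2ccccc2)cc1` differs from compound 3 by methyl in place of hydrogen on an aromatic carbon. Among the measured compounds shown here, the one measured step that bears on this is an at least 5.6-fold higher number from compound 2 to compound 3 (0.75 log units; beyond the scatter), which is beyond the scatter and shows that losing bromo at the same place raises the number. Adding methyl is therefore expected to shift growth inhibition modestly stronger, an estimated at least 2.3-fold lower number from compound 3 to compound 4 (0.37 log units; beyond the scatter). For compound 4 the expected value is 300000 nM, within an estimated range of 100000 nM to 800000 nM.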

Compound 4, concentration for 50% growth inhibition: > 688000 nM
Compound 4 was reported as a limit; the forecaster's own chance of this, stated with the estimate: 40%; middle value at least 2.2-fold (0.36 log units) from the limit.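

Methyl in place of bromo on this aromatic carbon, para to a large group, gives an at least 5.4-fold higher number from compound 2 to compound 4 (0.73 log units; beyond the scatter), so a methyl group does not keep the growth inhibition seen with bromo. Until now, only the loss of bromo to hydrogen had been seen here. Compound 3 and compound 4 are both reported only as limits of the assay, so the step between them cannot be read, and any effect of methyl relative to hydrogen stays hidden.

As far as these compounds go, it remains open whether a chloro or a methoxy group at this place would match bromo. From the compounds shown here alone, whether a larger halogen such as iodo would go further also remains open.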